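The compounds below may be only part of what the source reports. "The series", "measured", "known", "first", "only" and "open" are said of these compounds alone.

Of the compounds shown here, two of one shared core have been measured in a functional assay on K562 cells (Homo sapiens) for inhibition, read by MTT assay, with a stated time of 72 h; a lower number here means a stronger inhibitor, a higher number a weaker inhibitor. Compound 1 `Cc1ccc(-c2cn(-c3ccc(CN4CCCCC4)cc3)nn2)cc1Nc1nccc(-c2cccnc2)n1` gives 3290 nM, and compound 2 `Cc1ccc(-c2cn(-c3ccc(CN4CCCC4)cc3)nn2)cc1Nc1nccc(-c2cccnc2)n1` gives 3890 nM; the two lie within the scatter of each other, as the step of a 1.2-fold higher number from compound 1 to compound 2 (0.07 log units; within the scatter) shows. Compound 3 `CCN(CC)c1ccc(-n2cc(-c3ccc(C)c(Nc4nccc(-c5cccnc5)n4)c3)nn2)cc1` differs from compound 2 in one place: diethylamino in place of (pyrrolidin-1-yl)methyl on an aromatic carbon. Among the measured compounds shown here, the only measured step, a 1.2-fold higher number from compound 1 to compound 2 (0.07 log units; within the scatter), also exchanged a group in this outer part and produced no change beyond the scatter, so a similar outcome is expected here, as a 1.0-fold higher number from compound 2 to compound 3 (0.01 log units; within the scatter). Compound 3 is therefore estimated at 4000 nM, in a range from 1500 nM to 11000 nM.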

Compound 3, half-maximal inhibitory concentration: > 30000 nM
Compound 3: no number, only a limit; the forecaster's own chance of this, stated with the estimate: 5%; at least 7.5-fold (0.87 log units) between middle value and limit.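

Compound 3 stands at a limit, not a number: the limit of > 30000 nM in this assay, at which 1 of the 3 values shown sits. The group on this aromatic carbon therefore matters, since diethylamino in place of (pyrrolidin-1-yl)methyl gives an at least 7.7-fold higher number from compound 2 to compound 3 (0.88 log units; beyond the scatter), and in place of (piperidin-1-yl)methyl gives an at least 9.1-fold higher number from compound 1 to compound 3 (0.95 log units; beyond the scatter). Among the compounds shown here, exchanging one ring amine for the other had stayed within the scatter, so only this larger change shows that the position responds at all.

The change removes the ring and the chain carbon together, and the compounds shown cannot separate the two. A (diethylamino)methyl group, or pyrrolidin-1-yl bound directly to the aromatic carbon, would pull them apart.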